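The compounds below may be only part of what the source reports. "The series", "measured", "known", "first", "only" and "open" are said of these compounds alone.

Measured so far:
- compound 1, `Cc1cc(C)cc(S(=O)(=O)c2cnc3ccc(F)cc3c2N2CCC(C)CC2)c1`: 83%
- compound 2, `CC1CCN(c2c(S(=O)(=O)c3cccc(Cl)c3)cnc3ccc(F)cc23)CC1`: 92%
- compound 3, `Cc1ccc2ncc(S(=O)(=O)c3cccc(Cl)c3)c(N3CCC(C)CC3)c2c1`: 91%

All three were tested in an assay on isolated protein for displacement of a labelled ligand from metabotropic glutamate receptor 5 (Homo sapiens), with a stated time of 60 min, tested at 1 uM; a higher number here means more inhibition at the concentration tested (going by the name of the read-out), a lower number less inhibition. Compound 2 carries the largest of the three numbers, but this says little: the step of a number 9 percentage points higher from compound 1 to compound 2 (within the scatter) and the step of a number 1 percentage points lower from compound 2 to compound 3 (within the scatter) are both within the scatter of repeated measurements, so the three compounds sit at one level.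

Compound 4, `Cc1ccc(S(=O)(=O)c2cnc3ccc(F)cc3c2N2CCC(C)CC2)cc1F`, is the next compound, and it has not been measured. Relative to compound 2 the change is 3-fluoro-4-methylphenyl in place of 3-chlorophenyl on a sulfonyl sulfur. Within the data shown here, only one measured step touches the same place, the group on the sulfonyl sulfur: from compound 1 to compound 2, a change of that group gave a number 9 percentage points higher from compound 1 to compound 2 (within the scatter), a step within the scatter. The other measured step, a number 1 percentage points lower from compound 2 to compound 3 (within the scatter), concerns the core and also stays within the scatter. Nothing here points to a move beyond the scatter for compound 4 in this assay , so the expected step is a number 4 percentage points lower from compound 2 to compound 4 (within the scatter), essentially none. Compound 4 is therefore estimated at 88%, within a range of 75% to 97%.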

Compound 4, a percentage reported as inhibition, at one concentration (the size of the read-out at that concentration, not a potency): 86%
Compound 4: the middle estimate sits 2 percentage points above what was measured; the range from low to high includes it.
By their numbers in this assay, from the lowest: compounds 1, 4, 3 and 2 (each within the scatter of the next).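

In this assay, among these compounds, the group on the sulfonyl sulfur now comes in three forms on the same shared core, and the new compound stays level with both others: the record shows a number 6 percentage points lower from compound 2 to compound 4 (within the scatter) and a number 3 percentage points higher from compound 1 to compound 4 (within the scatter), with no step leaving the scatter. This position therefore holds its level with a ring carrying fluorine and methyl together, as well as with one carrying chlorine or two methyl groups. No measured evidence bears on why these groups read alike.

From the compounds shown here alone, all three groups on the sulfonyl sulfur are substituted phenyl rings, so it remains open whether a pyridine ring, a cyclohexyl ring or a phenyl ring bearing an amine would hold this level. A reading at one concentration is also not a potency, so any differences in potency among these compounds remain open.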